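The source may report more compounds than this note shows. Statements on the series, on what has been measured and on what is new or still open speak of the compounds shown alone.

Values in an ADME assay on a cell-free system (plasma, Rattus norvegicus, strain Wistar) for protein binding, read by LC-MS, using equilibrium dialysis, with a stated time of 6 h; a higher number here means a larger unbound share of the compound, a lower number a smaller unbound share:
- compound 1 `CCc1cc(-c2noc(-c3cc(C)cc(CN(C)C)c3)n2)cc(C)c1OC[C@@H](O)CNC(=O)CO`: 0.029
- compound 2 `CCc1cc(-c2noc(-c3cc(C)cc(CN(C)CC)c3)n2)cc(C)c1OC[C@@H](O)CNC(=O)CO`: 0.012
- compound 3 `CCc1cc(-c2noc(-c3cc(C)cc(CN(C)CC(C)C)c3)n2)cc(C)c1OC[C@@H](O)CNC(=O)CO`: < 0.001 (a limit, not a number)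

Compound 2 sits at 0.012, the lower of the two actual numbers, and compound 1 sits higher at 0.029. Compound 3 has only a limit, < 0.001.

Compound 4 `CCc1cc(-c2nc(-c3cc(C)c(OC[C@@H](O)CNC(=O)CO)c(CC)c3)no2)ccc1CN(C)C` has not been measured yet. The change is 4-((dimethylamino)methyl)-3-ethylphenyl in place of 3-((ethyl(methyl)amino)methyl)-5-methylphenyl on an aromatic carbon. The two have the same atoms, joined differently.

Compound 4 carries the dimethylamino group of compound 1, so the measured steps on the amine bear on it. The step of a 2.4-fold lower number from compound 1 to compound 2 (0.38 log units; beyond the scatter) was modest, and the step of an at least 12-fold lower number from compound 2 to compound 3 (1.07 log units; beyond the scatter) was large. Read backwards, the first of these suggests a higher number, yet the ethyl stays in the molecule, now on the ring, and no measured step covers that move. A small rise, within the scatter, is therefore expected.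

The expected step is a 1.3-fold higher number from compound 2 to compound 4 (0.12 log units; within the scatter).

For compound 4 the estimated value is 0.016, with an expected range from 0.006 to 0.04.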

Compound 4, unbound fraction: 0.005
Beside the measured number, compound 4's estimate is 3.2-fold (0.51 log units) above it; measured number below the stated range.
By their numbers in this assay, from the lowest: compound 4; then compound 2; then compound 1. At a limit, below all of these: compound 3.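

In this assay, putting 4-((dimethylamino)methyl)-3-ethylphenyl in place of 3-((ethyl(methyl)amino)methyl)-5-methylphenyl keeps every atom yet gives a 2.4-fold lower number from compound 2 to compound 4 (0.38 log units; beyond the scatter), so the way these atoms are joined matters here, not only which atoms are present. Keeping the dimethylamino group does not preserve the number either: with 4-((dimethylamino)methyl)-3-ethylphenyl in place of 3-((dimethylamino)methyl)-5-methylphenyl, there is a 5.8-fold lower number from compound 1 to compound 4 (0.76 log units; beyond the scatter). Nothing measured here accounts for this shift.

The shift of the amine-bearing chain and the change of the ring's alkyl group occur together, and the compounds shown do not separate them. On these data alone, how a cyclic amine such as piperidine, or a carboxylic acid in place of the amine, would fare on this ring also remains open.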